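From difluorophenyl to chlorophenyl on compound 3

A few compounds are considered here, and "the series" means these few. Any claim that something is new, unique, unknown or untested is made for them only; others in the source may bear on it.

compound 1 `CC(C)(C)N1CCC(c2cc(-c3ccc(F)cc3Cl)c3ccc(=O)n(-c4c(Cl)cccc4Cl)c3c2)CC1`: 3.84 L/kg
compound 2 `CC(C)(C)N1CCC(c2cc(-c3ccc(F)cc3F)c3ccc(=O)n(-c4c(Cl)cccc4Cl)c3c2)CC1`: 3.82 L/kg
compound 3 `CC(C)(C)N1CCC(c2cc3c(ccc(=O)n3-c3c(Cl)cccc3Cl)c(-c3ccc(F)cc3F)n2)CC1`: 24 L/kg

All three numbers come from an in vivo ADME assay on the whole organism for pharmacokinetics, with Rattus norvegicus as the target; a lower number here means that more of the compound stays in the plasma, a higher number that more of the compound sits outside the plasma. Compound 3 stands highest of the three, well beyond the scatter from the other two. Compound 4 `CC(C)(C)N1CCC(c2cc3c(ccc(=O)n3-c3c(Cl)cccc3Cl)c(-c3ccccc3Cl)n2)CC1` keeps the core of compound 3 but carries 2-chlorophenyl in place of 2,4-difluorophenyl on an aromatic carbon. Among the measured compounds shown here, one measured step bears on this, fluoro in place of chloro on an aromatic carbon: a 1.0-fold lower number from compound 1 to compound 2 (0.00 log units; within the scatter). That step stayed within the scatter, though it sits on the core of compound 1. For the measured compounds named here, no measured step shows a fluoro group simply lost. No step beyond the scatter is therefore expected in this assay. The estimated change is a 1.1-fold lower number from compound 3 to compound 4 (0.04 log units; within the scatter). Compound 4 is expected at 22 L/kg, with an estimated range of 11 L/kg to 42 L/kg.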

Compound 4, volume of distribution at steady state: 10.1 L/kg
Compound 4: middle estimate off by 2.2-fold (0.34 log units), on the high side; measured number below the stated range.
By their numbers in this assay, from the lowest: compounds 2 and 1 (each within the scatter of the next); then compound 4; then compound 3.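

Among the compounds shown here, on the core of compound 3, this position responds in this assay with a change beyond the scatter, a 2.4-fold lower number from compound 3 to compound 4 (0.38 log units; beyond the scatter), whereas the single halogen swap on the core of compound 1, a 1.0-fold lower number from compound 1 to compound 2 (0.00 log units; within the scatter), stayed within it. This change replaces two fluoro groups with one chloro group, so it is more than that simple swap. No measurement shown explains the step. Still open, as far as these compounds go, is which part of the change carries the step, and where a plain phenyl or a 2-methylphenyl group would fall at this place.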